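The source may report more compounds than this note shows. Statements on the series, on what has been measured and on what is new or still open speak of the compounds shown alone.

The two measured compounds share a core and differ only in where a bromo group sits on the pendant six-membered ring. Compound 1, `Cc1ccc2oc(-c3cccc(Br)c3)cc2c1`, gives 250 nM in an assay on cells for inhibition of Amine oxidase [flavin-containing] B (Homo sapiens), read by fluorescence and Amplex Red, with a stated time of 15 min; on this read-out higher numbers stand for weaker inhibition and lower numbers for stronger inhibition. Compound 2, `Cc1ccc2oc(-c3ccccc3Br)cc2c1`, gives 200 nM in this assay, which is the lower of the two numbers, though the gap to compound 1 lies within the scatter of repeated measurements, so the two cannot be told apart on this evidence.

Compound 3, `Cc1ccc2oc(-c3ccccc3)cc2c1`, has not been measured. It is reached from compound 2 by hydrogen in place of bromo on an aromatic carbon, at a place ortho to a large group. Among the compounds with values here, no measured pair shows this kind of step, so its size can only be guessed. Within the data shown here, the expectation is that removing the single bromine leaves the compound somewhat weaker, with a step of a 2.5-fold higher number from compound 2 to compound 3 (0.40 log units; beyond the scatter) from compound 2 to compound 3 in this assay that may only just exceed the scatter. On that basis compound 3 is estimated at 500 nM in this assay, within a range from 150 nM to 2000 nM.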

Compound 3, half-maximal inhibitory concentration: 880 nM
Estimate against measurement, compound 3: 1.8-fold (0.25 log units) below, and the stated range covers the measured number.
By their numbers in this assay, from the lowest: compounds 2 and 1 (each within the scatter of the next); then compound 3.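

In this assay, within the data shown here, the earlier compounds showed only that the two bromo placements could not be told apart, whereas taking the bromo group away altogether gives a modest change beyond the scatter: the step is a 4.4-fold higher number from compound 2 to compound 3 (0.64 log units; beyond the scatter) and, for the other bromo compound, a 3.5-fold higher number from compound 1 to compound 3 (0.55 log units; beyond the scatter) in the same direction. Hydrogen in place of bromo on this aromatic carbon, ortho to a large group, therefore goes with weaker inhibition, and both bromo compounds stand on the stronger side of compound 3, with neither going against this within the three compounds. Nothing here gives a measured reason for the size of this step.

As far as these compounds go, what remains open is whether this gain belongs to bromine itself or would also appear with another substituent at this place, such as chloro, methyl or methoxy. From the compounds shown here alone, it is equally open how an amine or a carboxylic acid on this ring would fare, and whether any other place on the ring would respond in the same way.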